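The source may hold more compounds than are shown below. What is called first, only, known or untested is meant among the compounds shown, and "the series" means these compounds.

Measured compounds:
compound 1 `COc1ccc2oc(Nc3ccccc3)nc2c1` with 7880 nM in an assay on isolated protein (strain Balb/c) for inhibition of Polyunsaturated fatty acid 5-lipoxygenase (Mus musculus), read by immunoassay, with a stated time of 20 min; on this read-out higher numbers stand for weaker inhibition and lower numbers for stronger inhibition
compound 2 `COc1ccc2oc(Nc3ccc(C(C)C)cc3)nc2c1` with 2640 nM in this assay

Going by the values given here, of these two numbers compound 2 gives the lower one, and its only neighbour is compound 1, which differs by one group: a 3.0-fold lower number from compound 1 to compound 2 (0.47 log units; beyond the scatter). Among the compounds with values here, that is the single measured step available, and it shows that putting a small carbon group on the outer ring of the shared core helps.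

Compound 3 `COc1ccc2oc(Nc3ccc(SC)cc3)nc2c1` is not yet measured. It differs from compound 2 in one place: methylsulfanyl in place of isopropyl on an aromatic carbon. Within the data shown here, no measured pair tells directly what happens when isopropyl is swapped for methylsulfanyl. The step from compound 1 to compound 2 only shows that a group at this place is better than none; it says nothing about which group. The expectation is therefore that compound 3 stays close to compound 2, with no step beyond the scatter: a 1.1-fold higher number from compound 2 to compound 3 (0.06 log units; within the scatter). Compound 3 is estimated at 3000 nM, within a range from 1200 nM to 8000 nM.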

Compound 3, half-maximal inhibitory concentration: 2770 nM
Estimate against measurement, compound 3: 1.1-fold (0.03 log units) above, and the stated range covers the measured number.
By their numbers in this assay, from the lowest: compounds 2 and 3 (each within the scatter of the next); then compound 1.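

In this assay, methylsulfanyl in place of isopropyl gives a 1.0-fold higher number from compound 2 to compound 3 (0.02 log units; within the scatter), so the two groups cannot be told apart at this position, even though methylsulfanyl, unlike isopropyl, brings a sulfur and a hydrogen-bond acceptor. Methylsulfanyl in place of hydrogen gives a 2.8-fold lower number from compound 1 to compound 3 (0.45 log units; beyond the scatter), so the earlier gain is not tied to isopropyl alone: two different groups at this place both beat hydrogen. No supporting measurement is available to explain why these two groups match.

Going by these compounds, whether this tolerance holds for other kinds of group, such as an amine, a carboxylic acid or a longer chain like butyl, remains open. Also open, on these data alone, is whether methylsulfanyl or isopropyl would do the same on another carbon of this ring.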